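The source may hold more compounds than are shown below. What is called first, only, known or untested is meant among the compounds shown, and "the series" means these compounds.

Compound 1 `Brc1cccc(CSc2nnc(-c3ccncc3)n2-c2ccccc2)c1` gives 7040 nM in a functional assay on HepG2 cells (Homo sapiens) for inhibition, read by MTT assay, with a stated time of 48 h; a lower number here means a stronger inhibitor, a higher number a weaker inhibitor.
Compound 2 `O=[N+]([O-])c1ccc(CSc2nnc(-c3ccncc3)n2-c2ccccc2)cc1` gives only a limit of the assay, > 50000 nM, not a number.
Compound 3 `O=C(CSc1nnc(-c2ccncc2)n1-c1ccccc1)N/N=C/c1ccc(O)cc1` likewise gives only a limit, > 50000 nM.

Compound 3 thus stands at the upper edge of what the assay can report, a mark shared by two of the three values (the limit of > 50000 nM in this assay, at which 2 of the 3 values shown sit); only compound 1 returned a number. Compound 4 `O=C(CSc1nnc(-c2ccncc2)n1-c1ccccc1)N/N=C/c1cccc(F)c1` differs from compound 3 by 3-fluorophenyl in place of 4-hydroxyphenyl on a carbon with a double bond to nitrogen. Going by the values given here, the single measured step, an at least 7.1-fold higher number from compound 1 to compound 2 (0.85 log units; beyond the scatter), changes a group on the saturated chain carbon bound to a sulfur, a different place from the carbon with a double bond to nitrogen altered here, so it does not bear directly on this change. Compound 4 is therefore expected to remain at the limit, estimated at 50000 nM with a range from 15000 nM to 150000 nM. The implied step, a number no higher from compound 3 to compound 4 (the limit leaves the size open), is expected to be none beyond the scatter.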

Compound 4, half-maximal inhibitory concentration: 24400 nM
For compound 4 the middle estimate is 2.0-fold (0.31 log units) above the measured one; the range from low to high includes it.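

Swapping the group on the carbon with a double bond to nitrogen moves the result: with 3-fluorophenyl in place of 4-hydroxyphenyl, the change is an at least 2.0-fold lower number from compound 3 to compound 4 (0.31 log units; beyond the scatter). Compound 3 gives only a limit of the assay, > 50000 nM. This position, and not only the group on the saturated chain carbon bound to a sulfur, can therefore change the result, and compound 4 gives a real number.

Going by these compounds, whether the fluorine, its place on the ring or the loss of the hydroxyl matters most stays open. So does what a plain phenyl or an amine-bearing ring on this carbon would give.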